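This account rests on a few compounds, and the source may have more. Where it says the series, first, only, none or still open, it means among the compounds named here.

Measured so far in a functional assay on A549 cells (Homo sapiens) for cytotoxicity, read by MTT assay, with a stated time of 72 h; a higher number here means a weaker inhibitor, a lower number a stronger inhibitor:

Compound 1, `CC1=CCC[C@H]2[C@](C)(CC3=CC(=O)C=C(NCCC(=O)O)C3=O)[C@@H](C)CC[C@]12C`, gives 26900 nM.
Compound 2, `CC(C)(C)C1=CC(=O)C=C(NCC(=O)O)C1=O`, gives > 200000 nM, which is a limit of the assay and not a number.
Compound 3, `C[C@H](NC1=CC(=O)C=C(C(C)(C)C)C1=O)C(=O)O`, gives > 200000 nM, again a limit and not a number.

Going by the values given here, compound 1 thus holds the only real number among the three; the other two results are limits. The step that the two limits leave unreadable from compound 2 to compound 3 cannot be read, since both ends sit at the limit of > 200000 nM in this assay, at which 2 of the 3 values shown sit.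

Compound 4 is `CC1=CCC[C@H]2[C@](C)(CC3=CC(=O)C=C(NCC(=O)O)C3=O)[C@@H](C)CC[C@]12C`. It differs from compound 1 in one place: carboxy in place of carboxymethyl on a saturated chain carbon bound to an amine nitrogen. Among the compounds with values here, no measured step covers this shortening of the chain. Compound 2 and compound 3 carry short acid chains on a smaller core, but each returns only a limit, so they give no direction for the change from compound 1 to compound 4. With nothing pointing either way, the expected step is one within the usual scatter: a 1.3-fold higher number from compound 1 to compound 4 (0.11 log units; within the scatter). Compound 4 is therefore estimated at 35000 nM, with a range from 12000 nM to 120000 nM.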

Compound 4, half-maximal inhibitory concentration: 46700 nM
Compound 4: the middle estimate sits 1.3-fold (0.13 log units) below what was measured; the range from low to high includes it.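

Shortening the acid chain gives the first readable step at this position: in this assay there is a 1.7-fold higher number from compound 1 to compound 4 (0.24 log units; within the scatter). Compound 1 and compound 4 therefore cannot be told apart here, so on this shared core the (2-carboxyethyl)amino and (carboxymethyl)amino chains give results that fall within repeat scatter of each other. The earlier step between compound 2 and compound 3 still cannot be read, because both results are limits and not numbers: the limit of > 200000 nM in this assay, at which 2 of the 4 values shown sit.

What the compounds shown leave open is whether a longer chain on the same nitrogen would stay within this scatter too. Going by these compounds, it is also open whether an amine or an amide in place of the carboxylic acid would move the number in this assay.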